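Working notes on a side-chain change in a small series

The source may hold more compounds than are shown below. What is called first, only, known or untested is meant among the compounds shown, and "the series" means these compounds.

Measured so far:
compound 1 `COc1cc(OC)c(-c2coc3cc(OCC=C(C)C)ccc3c2=O)cc1OC` — 280 nM
compound 2 `C=CCOc1ccc2c(=O)c(-c3cc(OC)c(OC)cc3OC)coc2c1` — 3450 nM
compound 3 `COc1cccc(C(=O)Oc2ccc3c(=O)c(-c4cc(OC)c(OC)cc4OC)coc3c2)c1` — a limit of the assay, > 10000 nM

In a functional assay on HepG2 cells (Homo sapiens) for antiproliferative activity, read by MTT assay, with a stated time of 24 h (a lower number here means a stronger inhibitor, a higher number a weaker inhibitor), compound 2 holds the highest of the two numbers shown; the nearest is compound 1, with a 12-fold higher number from compound 1 to compound 2 (1.09 log units; beyond the scatter). Compound 3 gives only a limit in this assay, (the limit of > 10000 nM in this assay, at which 1 of the 3 values shown sits).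

Compound 4 `COc1cc(OC)c(-c2coc3cc(OCC(=O)c4cccc(C(F)(F)F)c4)ccc3c2=O)cc1OC` is not yet measured. It differs from compound 2 as follows: (3-(trifluoromethyl)phenyl)carbonyl in place of vinyl on a saturated chain carbon bound to an oxygen on an aromatic ring.

Among the measured compounds shown here, two measured steps bear on this change. From compound 2 to compound 3 an aromatic carbonyl group took the place of the allyl group on the ring oxygen, and the number rose: an at least 2.8-fold higher number from compound 2 to compound 3 (0.46 log units; beyond the scatter). The step of an at least 35-fold higher number from compound 1 to compound 3 (1.55 log units; beyond the scatter) points the same way. Compound 4 likewise carries an aromatic carbonyl group on the side chain, so the number is expected to rise, a 2.3-fold higher number from compound 2 to compound 4 (0.37 log units; beyond the scatter), with a fair chance that only a limit is reported. The estimate for compound 4 is 8000 nM, expected between 2500 nM and 20000 nM.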

Compound 4, half-maximal inhibitory concentration: > 10000 nM
Compound 4 gave a limit, no number; the forecaster's own chance of this, stated with the estimate: 45%; at least 1.2-fold (0.09 log units) between middle value and limit.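

Compound 4 gives a limit of the assay, not a number. With the aromatic carbonyl on a saturated chain carbon bound to an oxygen on an aromatic ring, rather than on the ring oxygen itself as in compound 3, the series still gives no measurable value, with an at least 2.8-fold higher number from compound 2 to compound 4 (0.46 log units; beyond the scatter) and an at least 35-fold higher number from compound 1 to compound 4 (1.55 log units; beyond the scatter). Both steps are lower bounds only, and compound 3 and compound 4 cannot be ordered, since each rests on the same limit: the limit of > 10000 nM in this assay, at which 2 of the 4 values shown sit.

Going by these compounds, how far these two aromatic side chains lie beyond the limit remains open, as does any separate part played by the trifluoromethyl group. Also open, on these data alone, is whether an amine or a carboxylic acid on that chain carbon, or a longer chain ending in 2-methylprop-1-en-1-yl, would match or improve on compound 1 at 280 nM.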